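Changing One Ester Group on a Weak Compound

The source may report more compounds than this note shows. Statements on the series, on what has been measured and on what is new or still open speak of the compounds shown alone.

In a functional assay on SK-BR-3 cells (Homo sapiens) for antiproliferative activity, read by MTT assay, with a stated time of 72 h (on this read-out higher numbers stand for weaker inhibition and lower numbers for stronger inhibition), compound 1 `C/C=C1/[C@H](O[C@@H]2O[C@H](COC(C)=O)[C@@H](OC(C)=O)[C@H](OC(C)=O)[C@H]2OC(C)=O)OC=C(C(=O)OC)[C@H]1CC(=O)OCCCCCCCCCCCCCCC` gives 3810 nM as an exact result. Compound 2 `C/C=C1/[C@H](O[C@@H]2O[C@H](CO)[C@@H](O)[C@H](O)[C@H]2O)OC=C(C(=O)OC)[C@H]1CC(=O)OCc1ccc2c(c1)OCCO2` reads > 15000 nM as a limit of the assay and not a number. Compound 3 `C=CCOC(=O)C[C@@H]1C(C(=O)OC)=CO[C@@H](O[C@@H]2O[C@H](COC(C)=O)[C@@H](OC(C)=O)[C@H](OC(C)=O)[C@H]2OC(C)=O)/C1=C/C` reads > 20000 nM as a limit too. Compound 2 therefore has no exact place on the scale, only its limit.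

Compound 4 `C=C(C)CCOC(=O)C[C@@H]1C(C(=O)OC)=CO[C@@H](O[C@@H]2O[C@H](CO)[C@@H](O)[C@H](O)[C@H]2O)/C1=C/C` differs from compound 2 in one group (2-methylprop-2-en-1-yl in place of 2,3-dihydro-1,4-benzodioxin-6-yl on a saturated chain carbon bound to an oxygen next to a carbonyl group). In words, 2-methylprop-2-en-1-yl stands in place of 2,3-dihydro-1,4-benzodioxin-6-yl on a saturated chain carbon bound to an oxygen next to a carbonyl group. Among the compounds with values here, no measured pair shows this swap directly. The nearest hint is compound 3, which also has a double bond in its ester group and reads > 20000 nM as a limit, so no step beyond the scatter is expected in this assay for this change. The estimated step is a step that the limit leaves unreadable from compound 2 to compound 4 and nothing larger is expected. For compound 4 the expected value is 20000 nM with an estimated range of 8000 nM to 40000 nM and the result may well arrive only as a limit.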

Compound 4, half-maximal inhibitory concentration: > 15000 nM
Compound 4: a limit, no number (the forecaster's own chance of this, stated with the estimate: 70%); the middle value is on the limit's open side.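

Compound 4 reads > 15000 nM, a limit of the assay and not a number, and compound 2 also has only a limit, so no step between them can be read: the limit of > 15000 nM in this assay, at which 2 of the 4 values shown sit.

On these data alone, whether 2-methylprop-2-en-1-yl in place of 2,3-dihydro-1,4-benzodioxin-6-yl changes the activity at all stays open.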